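The source may hold more compounds than are shown below. What is called first, only, known or untested is meant among the compounds shown, and "the series" means these compounds.

Compound 1 `COc1ccc(OC)c2c1C(=O)C=C(CO)C2=O` carries a hydroxymethyl group on the shared core, and in a functional assay on L1210 cells (Mus musculus) for cytotoxicity (on this read-out lower numbers stand for an effect already at smaller amounts and higher numbers for an effect only at larger amounts of compound), compound 1 gives 0.524 ug/mL, the highest of the three numbers measured. Compound 2 `CCCCCCC(O)c1cc(OC)c2c(c1OC)C(=O)C=CC2=O` gives 0.22 ug/mL, and compound 3 `CCCCCCCC(O)c1cc(OC)c2c(c1OC)C(=O)C=CC2=O` gives 0.274 ug/mL; both carry a long hydroxyalkyl chain elsewhere on the shared core. The gap from compound 1 to compound 2 lies beyond the scatter, while the gap from compound 1 to compound 3 lies within it. Going by the values given here, the only single-point step measured, a 1.2-fold higher number from compound 2 to compound 3 (0.10 log units; within the scatter), adds a methyl to the end of that chain and changes nothing beyond the scatter. Compound 4 `CCCCCCC(O)C1=CC(=O)c2c(OC)ccc(OC)c2C1=O` comes from compound 1 by hexyl in place of hydrogen on a saturated chain carbon bound to a double-bonded ring carbon and an oxygen on a saturated carbon, so that the hydroxymethyl becomes a 1-hydroxyheptyl. Among the compounds with values here, no measured step adds a chain of this kind at this place; the long-chain compounds 2 and 3 give somewhat lower numbers than compound 1, and the measured step shows chain length alone moving little. For compound 4 the estimate is 0.3 ug/mL, with a range from 0.12 ug/mL to 0.8 ug/mL. In other words, a 1.7-fold lower number from compound 1 to compound 4 (0.24 log units; within the scatter) is expected.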

Compound 4, concentration for half-maximal effect: 0.732 ug/mL
Compound 4: middle estimate off by 2.4-fold (0.39 log units), on the low side; measured number inside the range.
By their numbers in this assay, from the lowest: compounds 2, 3, 1 and 4 (each within the scatter of the next, the first and the last beyond it).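

In this assay the change from hydroxymethyl to 1-hydroxyheptyl gives a 1.4-fold higher number from compound 1 to compound 4 (0.15 log units; within the scatter), so adding hexyl on this saturated chain carbon bound to a double-bonded ring carbon and an oxygen on a saturated carbon does not move the number beyond the scatter. The earlier step could not show this, as it only added a methyl to a chain that was already long and stood elsewhere on the shared core. Nothing available here bears on the reason for this result.

Still open, from the compounds shown here alone, is whether a shorter chain such as ethyl or a longer chain such as decyl would behave the same way in this place. Also open, going by these compounds, is whether a chain carrying an amine or a carboxylic acid would shift the number beyond the scatter.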